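The source may report more compounds than this note shows. Statements on the series, on what has been measured and on what is new or still open speak of the compounds shown alone.

Measured compounds:
Compound 1 `COc1cccc(Oc2c(NS(=O)(=O)c3ccc(C(C)(C)C)cc3)ncnc2OCCOc2ncccn2)c1` gives 1.9 nM in an assay on cells (Endothelial cell) for binding affinity to Endothelin-1 receptor (Sus scrofa); on this read-out higher numbers stand for weaker inhibition and lower numbers for stronger inhibition.
Compound 2 `CCc1ccc(-c2c(NS(=O)(=O)c3ccc(C(C)(C)C)cc3)ncnc2OCCOc2ncc(SC)cn2)cc1` gives 0.013 nM in this assay.

Compound 2 holds the lower of the two numbers; compound 1 sits far higher, a gap well beyond the scatter of repeated measurement. Going by the values given here, the two compounds differ in several places at once, so no single-change step between them can be read off, and the pair shows only what its two values show.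

Compound 3 `CSc1cnc(OCCOc2ncnc(NS(=O)(=O)c3ccc(C(C)(C)C)cc3)c2-c2ccc(Cl)cc2)nc1` is not yet measured. It differs from compound 2 by chloro in place of ethyl on an aromatic carbon, para to a large group; cut one bond further out, the difference reads 4-ethylphenyl to 4-chlorophenyl. The remainder of the molecule is unchanged.

Among the compounds with values here, no measured step of this kind is available. The step is expected to be small, in either direction, most likely not beyond the scatter, with a slight rise in the number held as the more probable outcome. Compound 3 is accordingly expected to give 0.03 nM in this assay, within 0.008 nM to 0.15 nM. The expected step is a 2.3-fold higher number from compound 2 to compound 3 (0.36 log units; beyond the scatter).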

Compound 3, half-maximal inhibitory concentration: < 0.001 nM
Compound 3: no number, only a limit; the forecaster's own chance of this, stated with the estimate: 0%; middle value at least 30-fold (1.47 log units) away from the limit.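

Chloro in place of ethyl on the aromatic carbon para to a large group gives an at least 13-fold lower number from compound 2 to compound 3 (1.11 log units; beyond the scatter) in this assay, so this position still responds strongly to a single substituent change in a compound that already sits very low, and ethyl is not needed there for strong inhibition. Compound 3 reaches a limit of the assay, < 0.001 nM, which is a limit and not a number. As far as these compounds go, the true size of the step therefore stays unknown, and only its lower bound can be read, because the value of compound 3 rests on the assay's limit: the limit of < 0.001 nM in this assay, at which 1 of the 3 values shown sits.

With one pair at this position, the compounds shown cannot tell whether the change in the number follows from chloro entering or ethyl leaving, and fluoro, bromo, methyl, methoxy, a longer chain such as propyl, an amine or a carboxylic acid on the same carbon would be needed to separate the two. From the compounds shown here alone, it also remains open whether the same exchange would act alike on the core of compound 1, which carries its aromatic ring through an oxygen and has no methylthio group.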